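The compounds below may be only part of what the source reports. "The series", "measured", "known", "first", "only" and "open" are said of these compounds alone.

Compound 1 `COc1ccc(Nc2nc(-c3cccc(F)c3)nc3ccc(F)cc23)cc1`: 48400 nM
Compound 2 `Fc1cccc(-c2nc(Nc3ccc(Br)cc3)c3cc(F)ccc3n2)c1`: > 50000 nM, a limit of the assay
Compound 3 `Nc1cccc(Nc2nc(-c3cccc(F)c3)nc3ccc(F)cc23)c1`: > 50000 nM, a limit of the assay

In a functional assay on MCF7 cells (Homo sapiens) for cytotoxicity, read by MTT assay, with a stated time of 48 h (a lower number here means a stronger inhibitor, a higher number a weaker inhibitor), compound 1 gives 48400 nM. Within the data shown here, that is the only plain number among the three compounds; the other two values sit at the limit of > 50000 nM in this assay, at which 2 of the 3 values shown sit. Two changes to compound 1 were measured. Bromo in place of methoxy on an aromatic carbon gives an at least 1.0-fold higher number from compound 1 to compound 2 (0.01 log units; that floor lies within the scatter). The second change gives an at least 1.0-fold higher number from compound 1 to compound 3 (0.01 log units; that floor lies within the scatter). Between compound 2 and compound 3 the two limits leave the step unreadable, a step that the two limits leave unreadable from compound 2 to compound 3.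

Compound 4 `Cc1ccccc1Nc1nc(-c2cccc(F)c2)nc2ccc(F)cc12` has not yet been measured. It differs from compound 1 by 2-methylphenyl in place of 4-methoxyphenyl on a nitrogen on an aromatic ring. Both measured changes at the same part of compound 1 gave a weaker or unchanged value within limits, so a step of about that kind is expected here, in the direction of a higher number or none beyond the scatter. The expected step is a 1.1-fold higher number from compound 1 to compound 4 (0.06 log units; within the scatter). In this assay compound 4 is therefore estimated at 55000 nM, between 25000 nM and 120000 nM, with a fair chance that only a limit is reported.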

Compound 4, half-maximal inhibitory concentration: > 50000 nM
Compound 4 gave a limit, no number (the forecaster's own chance of this, stated with the estimate: 55%); the middle value is on the limit's open side.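

In this assay compound 4 ends at a limit of the assay, not at a number. The step reads an at least 1.0-fold higher number from compound 1 to compound 4 (0.01 log units; that floor lies within the scatter), while the steps among the compounds at the limit cannot be read. So 2-methylphenyl, which carries no hydrogen-bond acceptor where 4-methoxyphenyl carries one, joins 4-bromophenyl and 3-aminophenyl as a third group on this nitrogen with no reading of a lower number than compound 1, and the series now crowds at one ceiling: the limit of > 50000 nM in this assay, at which 3 of the 4 values shown sit.

As far as these compounds go, how far the three compounds at the limit differ from one another stays open, as does whether any group on this nitrogen can give a clearly lower number. A carboxylic acid or a morpholine on the phenyl ring, or a plain alkyl chain in its place, would test this further.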